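Swapping Bromo for Methyl: an Expected Loss of Potency

A few compounds are considered here, and "the series" means these few. Any claim that something is new, unique, unknown or untested is made for them only; others in the source may bear on it.

Measured compounds:
compound 1 `Cc1ccc2nc(-c3ccc(NC(=O)CCc4ccccc4)cc3)[nH]c2c1` gives 60000 nM
compound 2 `O=C(CCc1ccccc1)Nc1ccc(-c2nc3ccc(Br)cc3[nH]2)cc1` gives 11500 nM
compound 3 `O=[N+]([O-])c1cccc(-c2nc3ccc(Br)cc3[nH]2)c1` gives > 100000 nM

All numbers come from an assay on cells for inhibition of matrix metalloproteinase-9 (Homo sapiens), read by fluorescence, with stated times of 15 min and 4 h; a higher number here means a weaker inhibitor, a lower number a stronger inhibitor. For compound 3 the result is a limit of the assay, not a number; compound 3 sits at the limit of > 100000 nM in this assay, at which 1 of the 3 values shown sits. The difference between the core of compound 3 and the core of compound 2 is not broken down here. Compound 1 and compound 2 differ by a single change, (methyl in place of bromo on an aromatic carbon), and that change produced a 5.2-fold higher number from compound 2 to compound 1 (0.72 log units; beyond the scatter). Compound 4 `Cc1ccc2nc(-c3cccc([N+](=O)[O-])c3)[nH]c2c1` has not yet been measured; it differs from compound 3 by the same change, (methyl in place of bromo on an aromatic carbon), in the same place. Because a 5.2-fold higher number from compound 2 to compound 1 (0.72 log units; beyond the scatter) weakened the inhibitor, a loss of the same kind is expected here, a step that the limit leaves unreadable from compound 3 to compound 4, most likely leaving compound 4 at a limit rather than a number. Compound 4 is therefore estimated at 400000 nM.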

Compound 4, half-maximal inhibitory concentration: 36600 nM
Estimate against measurement, compound 4: 11-fold (1.04 log units) above, and the stated range ends above it.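

Compound 3 gives > 100000 nM in this assay, and this is a limit of the assay, not a number. Even so, methyl in place of bromo can be read here as an at least 2.7-fold lower number from compound 3 to compound 4 (0.43 log units; beyond the scatter), the opposite direction to a 5.2-fold higher number from compound 2 to compound 1 (0.72 log units; beyond the scatter). The effect of this change therefore did not carry over from one core to the other, though these two pairs show neither the reason for the reversal nor how large the second step really is: the same change on two cores in this assay, a 5.2-fold higher number (0.72 log units; beyond the scatter) from compound 2 to compound 1 and an at least 2.7-fold lower number (0.43 log units; beyond the scatter) from compound 3 to compound 4, at least 14-fold (1.15 log units) apart, beyond the scatter of two such steps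

Still open, from the compounds shown here alone, is whether the reversal goes with the nitro group of compound 3 or with the amide chain of compound 2. Also open, going by these compounds, is what a chloro group or an amine on the same aromatic carbon would do on each core.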